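The source may report more compounds than this note shows. Statements on the series, on what has been measured and on what is new or still open speak of the compounds shown alone.

Compound 3 `CC(C)CCOc1cccc(C(=O)Nc2cccc(C(=O)O)c2)c1` gives 2760 nM in an assay on isolated protein for agonist activity at Bile acid receptor (Homo sapiens), read by TR-FRET, with a stated time of 3 h, in the absence of a further agent (a higher number here means that more compound is needed for the effect, a lower number that less compound is needed), the highest of the three numbers, although its steps to compound 2 `CCCCCOc1cccc(C(=O)Nc2cccc(C(=O)O)c2)c1`, which gives 2540 nM, and to compound 1 `CCOc1cccc(C(=O)Nc2cccc(C(=O)O)c2)c1`, which gives 2350 nM, both lie within the scatter. Compound 4 `O=C(O)c1cccc(NC(=O)c2cccc(OCC3CC3)c2)c1` differs from compound 3 by cyclopropyl in place of isobutyl on a saturated chain carbon bound to an oxygen on an aromatic ring. Among the compounds with values here, the steps that bear on this position, a 1.1-fold higher number from compound 1 to compound 2 (0.03 log units; within the scatter), a 1.2-fold higher number from compound 1 to compound 3 (0.07 log units; within the scatter) and a 1.1-fold higher number from compound 2 to compound 3 (0.04 log units; within the scatter), all fall within the scatter, so the three changes seen so far on the saturated chain bound to the oxygen on the aromatic ring have left this assay unmoved. Within the data shown here, a ring at this place has no precedent, but on this record no step beyond the scatter is expected, a 1.1-fold lower number from compound 3 to compound 4 (0.03 log units; within the scatter). Compound 4 is therefore estimated at 2600 nM, with a range of 1200 nM to 5600 nM.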

Compound 4, half-maximal effective concentration: 1260 nM
The estimate for compound 4 lay 2.1-fold (0.31 log units) above the measured number, and the stated range covers the measured number.
By their numbers in this assay, from the lowest: compounds 4, 1, 2 and 3 (each within the scatter of the next, the first and the last beyond it).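

In this assay, within the data shown here, cyclopropylmethoxy is the first change at this position to give a step beyond the scatter, a 2.2-fold lower number from compound 3 to compound 4 (0.34 log units; beyond the scatter), and that step is modest. The other two comparisons, a 2.0-fold lower number from compound 2 to compound 4 (0.30 log units; within the scatter) and a 1.9-fold lower number from compound 1 to compound 4 (0.27 log units; within the scatter), stay within the scatter, so the separation holds only against isopentyloxy. No measured evidence offers a reason for this step.

From the compounds shown here alone, whether the three-membered ring itself matters remains open. A cyclobutyl or cyclopentyl group on the same saturated chain carbon, or an amine in the chain, would test how far this position responds.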